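The compounds below may be only part of what the source reports. "The series", "measured", "known", "first", "only" and "open" are said of these compounds alone.

Measured in an assay on microsomes from liver for inhibition of sterol O-acyltransferase 1 (Rattus norvegicus); on this read-out higher numbers stand for weaker inhibition and lower numbers for stronger inhibition:
Compound 1, `O=C(O)CCCCCCn1nc(-c2ccccc2)c(-c2ccccc2)cc1=O`: reports only a limit, > 300000 nM.
Compound 2, `CCCCCCSc1cc(-c2ccccc2)c(-c2ccccc2)nn1`: 62000 nM.
Compound 3, `CCCCCCCCCS(=O)(=O)c1cc(-c2ccccc2)c(-c2ccccc2)nn1`: 76000 nM.

Compound 2 holds the lowest of the two numbers given, but the value of compound 3 lies within the scatter of it, so nothing separates the two. Compound 4, `O=C(O)CCCCCSc1cc(-c2ccccc2)c(-c2ccccc2)nn1`, is not yet measured. It differs from compound 2 by carboxy in place of methyl on a saturated chain carbon, five bonds along the chain from a sulfur. Within the data shown here, no step between measured compounds that differ in one place is available. Compound 1 carries a carboxy at its chain end on a different core and sits at the limit of > 300000 nM in this assay, at which 1 of the 3 values shown sits. On that showing a step toward weaker inhibition is expected, a 2.4-fold higher number from compound 2 to compound 4 (0.38 log units; beyond the scatter). Compound 4 is expected to give 150000 nM in this assay, with a range from 50000 nM to 400000 nM.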

Compound 4, half-maximal inhibitory concentration: > 300000 nM
Compound 4 ended at the assay's limit; the forecaster's own chance of this, stated with the estimate: 35%; middle value at least 2.0-fold (0.30 log units) away from the limit.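

In this assay, carboxy in place of methyl on a saturated chain carbon, five bonds along the chain from a sulfur, gives an at least 4.8-fold higher number from compound 2 to compound 4 (0.68 log units; beyond the scatter). Among these compounds, this is the first step read on the shared core, and only its lower bound is known, as the value of compound 4 is a limit. Compound 4 shares that limit with one other compound: the limit of > 300000 nM in this assay, at which 2 of the 4 values shown sit.

Going by these compounds, whether a methyl ester or an amide at this chain end would stay clear of the limit remains open. So does whether a longer chain ending in carboxy would.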